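The source may report more compounds than this note shows. Statements on the series, on what has been measured and on what is new or still open speak of the compounds shown alone.

Measured compounds:
compound 1, `CNC(=O)c1cc(Oc2ccc(NC(=O)c3cc4cccnc4n(-c4ccc(OC)cc4)c3=O)cc2)ccn1`: 3110 nM
compound 2, `CCNC(=O)c1cc(Oc2ccc(NC(=O)c3cc4cccnc4n(-c4ccccc4F)c3=O)cc2)ccn1`: 490 nM
compound 3, `CCNC(=O)c1cc(Oc2ccc(NC(=O)c3cc4cccnc4n(-c4ccc(Cl)cc4)c3=O)cc2)ccn1`: 250 nM

In a functional assay on A549 cells (Homo sapiens) for antiproliferative activity, read by MTT assay, with a stated time of 72 h (on this read-out lower numbers stand for stronger inhibition and higher numbers for weaker inhibition), compound 3 gives the lowest of the three numbers. Compound 2 stands nearest to it, and the step of a 2.0-fold lower number from compound 2 to compound 3 (0.29 log units; within the scatter) lies within the scatter, so these two are not separated. Compound 1 stands furthest from compound 3, and that gap is beyond the scatter.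

Compound 4, `CCNC(=O)c1cc(Oc2ccc(NC(=O)c3cc4cccnc4n(-c4ccc(OC)cc4)c3=O)cc2)ccn1`, arises from compound 3 by methoxy in place of chloro on an aromatic carbon. Among the measured compounds shown here, no measured step bears directly on this exchange. For the measured compounds named here, the single measured step, a 2.0-fold lower number from compound 2 to compound 3 (0.29 log units; within the scatter), concerns a different group on the aromatic nitrogen and was within the scatter, so it gives no size for the present change. Compound 1 carries the same methoxyphenyl group as compound 4, and compound 1 gives 3110 nM in this assay, a weaker number than compound 3 shows; but compound 1 differs from compound 3 in a second place as well, so its number cannot be laid to the methoxy alone.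

On this basis a step toward a higher number is expected for compound 4, a 4.8-fold higher number from compound 3 to compound 4 (0.68 log units; beyond the scatter), with the expected value near 1200 nM and a range from 400 nM to 4000 nM.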

Compound 4, half-maximal inhibitory concentration: 2010 nM
Estimate against measurement, compound 4: 1.7-fold (0.22 log units) below, within the range that was stated.
By their numbers in this assay, from the lowest: compounds 3 and 2 (each within the scatter of the next); then compounds 4 and 1 (each within the scatter of the next).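

In this assay, the change from 4-chlorophenyl to 4-methoxyphenyl gives an 8.0-fold higher number from compound 3 to compound 4 (0.91 log units; beyond the scatter) and so provides the first separation beyond the scatter for a single exchange at this place, on an aromatic carbon para to a large group. The 4-methoxyphenyl group also stands apart from the 2-fluorophenyl group on the aromatic nitrogen (a 4.1-fold higher number from compound 2 to compound 4 (0.61 log units; beyond the scatter)), whereas the earlier exchange of 2-fluorophenyl for 4-chlorophenyl did not separate its two compounds. With the 4-methoxyphenyl group held fixed, the added methyl on the chain bound to the amide-type nitrogen does not separate the pair (a 1.5-fold lower number from compound 1 to compound 4 (0.19 log units; within the scatter)), so the high number of compound 1 can now be set beside that of compound 4 rather than left unexplained by its second difference.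

Nothing measured here speaks to why methoxy and chloro part at this place. On these data alone, whether a hydroxy group, an amine or a methyl group at the same aromatic carbon would stand with the chloro compound or with the methoxy compound remains open.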